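The source may hold more compounds than are shown below. What is called first, only, known or untested is meant among the compounds shown, and "the series" means these compounds.

Compound 1 `Cc1cc(NC(=O)c2cccc(C(F)(F)F)c2)ccc1NS(C)(=O)=O` and compound 2 `CCS(=O)(=O)Nc1ccc(NC(=O)c2cccc(C(F)(F)F)c2)cc1C` share one core and differ by a single change, (methyl in place of hydrogen on a saturated chain carbon bound to a sulfonyl sulfur). In an ADME assay on RAW264.7 cells (Mus musculus) for cytotoxicity, read by MTT assay, with a stated time of 48 h (on this read-out higher numbers stand for weaker inhibition and lower numbers for stronger inhibition), compound 1 gives 110000 nM, and compound 2 gives 114000 nM; the step is a 1.0-fold higher number from compound 1 to compound 2 (0.02 log units; within the scatter). Compound 3 `COc1cc(NC(=O)c2ccc(Cl)cc2)ccc1NS(C)(=O)=O` is built on a different core; how its core differs from the core of compound 1 is not broken down here. In this assay compound 3 gives 70000 nM, a number within the scatter of the other two. Compound 4 `CCS(=O)(=O)Nc1ccc(NC(=O)c2ccc(Cl)cc2)cc1OC` has not yet been measured and carries, relative to compound 3, the same change made at the same place: methyl in place of hydrogen on a saturated chain carbon bound to a sulfonyl sulfur. Because the earlier step of a 1.0-fold higher number from compound 1 to compound 2 (0.02 log units; within the scatter) stayed within the scatter, the expected step is a 1.0-fold higher number from compound 3 to compound 4 (0.01 log units; within the scatter). Compound 4 is therefore estimated at 72000 nM, most likely between 40000 nM and 130000 nM.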

Compound 4, half-maximal inhibitory concentration: 60100 nM
For compound 4 the middle estimate is 1.2-fold (0.08 log units) above the measured one; measured number inside the range.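

In this assay, going from methylsulfonyl to ethylsulfonyl gives a 1.2-fold lower number from compound 3 to compound 4 (0.07 log units; within the scatter). The same change therefore behaves alike on the two cores, with no difference that can be told from noise: the same change on two cores in this assay, a 1.0-fold higher number (0.02 log units; within the scatter) from compound 1 to compound 2 and a 1.2-fold lower number (0.07 log units; within the scatter) from compound 3 to compound 4, 1.2-fold (0.08 log units) apart, within the scatter of two such steps. Going by these compounds alone, this shows only that the step stays small for this one change on these two cores; it does not show that the step would stay small on other cores, and two pairs of compounds make no rule for the whole series.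

The compounds shown carry only methyl or ethyl on the sulfonyl sulfur, so a longer chain such as propyl, a cyclopropyl ring, or a chain ending in an amine remains open. Whether any of these would give a step beyond the scatter in this assay cannot be told from these compounds.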